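The source may hold more compounds than are shown below. What is called first, only, known or untested is meant among the compounds shown, and "the series" means these compounds.

Among the compounds with values here, in an assay on isolated protein (strain Sprague-Dawley) for inhibition of Amine oxidase [flavin-containing] B (Rattus norvegicus), read by spectrophotometry, with a stated time of 5 min (a higher number here means a weaker inhibitor, a lower number a stronger inhibitor), compound 2 `CN(C)C(=O)COc1cc(=O)oc2cc(OCc3cccc(Cl)c3)ccc12` gives 501 nM, the higher of the two numbers so far; its only neighbour, compound 1 `CCOc1cc(=O)oc2cc(OCc3cccc(Cl)c3)ccc12`, gives 115 nM in this assay, the step between them being a 4.4-fold higher number from compound 1 to compound 2 (0.64 log units; beyond the scatter). Compound 3 `O=c1cc(Oc2ccccc2)c2ccc(OCc3cccc(Cl)c3)cc2o1` differs from compound 2 by phenyl in place of (dimethylcarbamoyl)methyl on an oxygen on an aromatic ring. Within the data shown here, only one measured step bears on this change, and only loosely: a 4.4-fold higher number from compound 1 to compound 2 (0.64 log units; beyond the scatter) shows the number rising beyond the scatter when dimethylcarbamoyl enters the chain, and compound 3 removes that chain entirely, putting phenyl in its place. Among the measured compounds shown here, no measured pair covers a phenyl at this oxygen, so the direction rests on the removal of the dimethylcarbamoyl alone. The expected step is therefore a modest one downward, a 2.5-fold lower number from compound 2 to compound 3 (0.40 log units; beyond the scatter), with wide uncertainty. Compound 3 is expected to give 200 nM in this assay, within a range from 50 nM to 800 nM.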

Compound 3, half-maximal inhibitory concentration: 4070 nM
For compound 3 the middle estimate is 20-fold (1.31 log units) below the measured one; measured number above the stated range.
By their numbers in this assay, from the lowest: compound 1; then compound 2; then compound 3.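

In this assay, phenyl is the least tolerated of the three groups shown on this oxygen, as the change to phenoxy raises the number twice (an 8.1-fold higher number from compound 2 to compound 3 (0.91 log units; beyond the scatter); a 35-fold higher number from compound 1 to compound 3 (1.55 log units; beyond the scatter)). Removing the (dimethylcarbamoyl)methyl group therefore does not by itself lower the number: what takes its place matters, and here the phenyl ring gives a higher number than either open chain, ethyl in compound 1 or (dimethylcarbamoyl)methyl in compound 2. Nothing given here explains why the phenyl ring at this oxygen goes with so high a number.

The compounds shown leave open whether it is the ring itself or its direct attachment to the oxygen that matters, which a benzyl group could separate. They also leave open how a cyclohexyl ring, a longer alkyl chain or an amine-bearing chain would compare with ethyl on this oxygen.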